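Three Limits and a Dimethoxyphenyl Replacement

A few compounds are considered here, and "the series" means these few. Any claim that something is new, unique, unknown or untested is made for them only; others in the source may bear on it.

Compound 1 `CCOc1ccc(-n2nncc2CN2C(=O)C3(C(C#N)=C(N)Oc4c3c3nc5ccccc5nc3c3ccccc43)c3ccccc32)cc1`: > 50000 nM
Compound 2 `N#CC1=C(N)Oc2c(c3nc4ccccc4nc3c3ccccc23)C12C(=O)N(Cc1cnnn1-c1ccc(Cl)c(Cl)c1)c1ccccc12`: > 50000 nM
Compound 3 `N#CC1=C(N)Oc2c(N)cc3nc4ccccc4nc3c2C12C(=O)N(Cc1cnnn1-c1ccc(F)cc1)c1ccccc12`: > 50000 nM

In a functional assay on MCF7 cells (Homo sapiens) for antiproliferative activity, read by MTT assay, with a stated time of 48 h (a lower number here means a stronger inhibitor, a higher number a weaker inhibitor), compound 1 reaches only a limit, > 50000 nM. Compound 2 likewise gives only a limit in this assay, > 50000 nM. Compound 3 too stands at a limit in this assay, > 50000 nM. Among the compounds with values here, the one step between measured compounds, a step that the two limits leave unreadable from compound 1 to compound 2, therefore carries no readable size, and the whole set sits at the limit of > 50000 nM in this assay, at which 3 of the 3 values shown sit.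

Compound 4 `COc1ccc(OC)c(-n2nncc2CN2C(=O)C3(C(C#N)=C(N)Oc4c(N)cc5nc6ccccc6nc5c43)c3ccccc32)c1` differs from compound 3 by 2,5-dimethoxyphenyl in place of 4-fluorophenyl on an aromatic nitrogen. Within the data shown here, no measured step bears on this change, and the three values give no direction beyond the scatter. Because compound 3 gives > 50000 nM in this assay, compound 4 is expected to stay at or near that limit, so the estimated step that the limit leaves unreadable from compound 3 to compound 4 is no more than scatter. For compound 4 the estimate in this assay is 70000 nM, with a range from 20000 nM to 250000 nM.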

Compound 4, half-maximal inhibitory concentration: 28100 nM
Estimate against measurement, compound 4: 2.5-fold (0.40 log units) above; the range from low to high includes it.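

In this assay, 2,5-dimethoxyphenyl in place of 4-fluorophenyl on the aromatic nitrogen gives an at least 1.7-fold lower number from compound 3 to compound 4 (0.25 log units; that floor lies within the scatter). Within the data shown here, compound 4 thus carries the only readable number in the set, while the other compounds all stand at a single limit: the limit of > 50000 nM in this assay, at which 3 of the 4 values shown sit. This change therefore gives a measured number at this position but no proven gain, as the true value of compound 3 remains unknown and the printed floor of the step does not pass beyond the scatter.

As far as these compounds go, whether a single methoxy group on this phenyl ring would give a readable number remains open, as does the effect of an amine or a carboxylic acid there. From the compounds shown here alone, it is also open whether 2,5-dimethoxyphenyl would give a readable number on the core of compound 1.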